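Three Sulfonamides at the Assay Limit, a Fourth Awaited

A few compounds are considered here, and "the series" means these few. Any claim that something is new, unique, unknown or untested is made for them only; others in the source may bear on it.

Compound 1, `O=S(=O)(Nc1ccc(F)c(Cl)c1)c1ccc(-c2cnc(C3CC3)o2)cc1`: in a functional assay on cells (leukaemia cell line, Homo sapiens) for inhibition, read by sulforhodamine B assay, with a stated time of 48 h (a higher number here means that more compound is tolerated, a lower number that less compound is tolerated), compound 1 gives > 100000 nM, a limit of the assay rather than a number.
Compound 2, `Cc1cc(NS(=O)(=O)c2ccc(-c3cnc(C4CC4)o3)cc2)ccc1Cl`: in this assay compound 2 gives > 100000 nM, again a limit.
Compound 3, `O=S(=O)(Nc1ccc(Br)c(Cl)c1)c1ccc(-c2cnc(C3CC3)o2)cc1`: in this assay compound 3 gives > 100000 nM, also a limit.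

Compound 1 therefore stands nowhere definite on the scale: all that is known of it is the limit of > 100000 nM in this assay, at which 3 of the 3 values shown sit. Going by the values given here, the steps that bear on the change to be followed are a step that the two limits leave unreadable from compound 1 to compound 2, a step that the two limits leave unreadable from compound 1 to compound 3 and a step that the two limits leave unreadable from compound 2 to compound 3; none of them can be read in size or direction, since both ends of each sit at the limit.

The new compound, compound 4, `Cc1cc(Cl)cc(NS(=O)(=O)c2ccc(-c3cnc(C4CC4)o3)cc2)c1`, differs from compound 1 in one place: 3-chloro-5-methylphenyl in place of 3-chloro-4-fluorophenyl on a sulfonamide nitrogen. With no readable step among the measured pairs, no step beyond the scatter can be expected in this assay in either direction from compound 1 to compound 4. On this basis compound 4 is expected to give about 150000 nM in this assay, within the range 100000 nM to 300000 nM, and most likely to be reported only as a limit. The step from compound 1 to compound 4 that this estimate implies is a step that the limit leaves unreadable from compound 1 to compound 4, expected to be indistinguishable from no change.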

Compound 4, concentration lethal to 50% of the cells: 84900 nM
The estimate for compound 4 lay 1.8-fold (0.25 log units) above the measured number; the whole stated range lies above it.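

Going by these compounds alone, compound 4, with 3-chloro-5-methylphenyl on a sulfonamide nitrogen, gives the first value in this assay that is a number and not a limit, whereas the rest of the series remains at a limit: (the limit of > 100000 nM in this assay, at which 3 of the 4 values shown sit). This gives each comparison with compound 4 one readable end, so the new steps have a floor (an at least 1.1-fold lower number from compound 1 to compound 4 (0.07 log units; that floor lies within the scatter)) (an at least 1.1-fold lower number from compound 2 to compound 4 (0.07 log units; that floor lies within the scatter)) (an at least 1.1-fold lower number from compound 3 to compound 4 (0.07 log units; that floor lies within the scatter)), whereas the steps among the three earlier compounds cannot be read. Each floor lies within the scatter, so the change to 3-chloro-5-methylphenyl cannot yet be said to have lowered the number, even against the 4-chloro-3-methylphenyl group of compound 2, which carries the same named substituents.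

The full size of all three steps stays open, since one end of each is a limit, and so does any reason for compound 4 giving a number. Also open, from the compounds shown here alone, is what an amine or a carboxylic acid would give on the aromatic ring of this group, or a longer chain on a sulfonamide nitrogen in its place, with the core of compound 1 unchanged.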